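This account rests on a few compounds, and the source may have more. Where it says the series, first, only, none or still open, it means among the compounds named here.

Measured compounds:
- compound 1 `CCOc1ccc(NC(=O)Nc2cccc(CNc3nccnc3Cl)c2)cc1` — 7050 nM
- compound 2 `O=C(Nc1cccc(CNc2nccnc2Cl)c1)Nc1ccc(Cl)cc1Cl` — 7230 nM

In a functional assay on HepG2 cells (Homo sapiens) for antiproliferative activity, read by MTT assay, with a stated time of 48 h (on this read-out lower numbers stand for stronger inhibition and higher numbers for weaker inhibition), compound 1 gives 7050 nM, the lower of the two numbers recorded, and compound 2 gives 7230 nM; the step of a 1.0-fold higher number from compound 1 to compound 2 (0.01 log units; within the scatter) shows that the two compounds cannot be told apart on this read-out. Compound 3 `Cc1ccccc1NC(=O)Nc1cccc(CNc2nccnc2Cl)c1` has not yet been measured. It differs from compound 1 in one place: 2-methylphenyl in place of 4-ethoxyphenyl on an amide-type nitrogen.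

For the measured compounds named here, one measured step bears on this change, since it swaps the group on the same amide-type nitrogen: a 1.0-fold higher number from compound 1 to compound 2 (0.01 log units; within the scatter). That swap, exchanging 4-ethoxyphenyl for 2,4-dichlorophenyl, left the number in this assay essentially where it was. Going by the values given here, with only that one step as a guide, the exchange of 4-ethoxyphenyl for 2-methylphenyl is expected to stay near compound 1 as well, with no shift beyond the scatter in either direction. Compound 3 is therefore estimated at 7000 nM, in a range from 3000 nM to 16000 nM, which amounts to an expected step of a 1.0-fold lower number from compound 1 to compound 3 (0.00 log units; within the scatter).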

Compound 3, half-maximal inhibitory concentration: 15300 nM
The estimate for compound 3 lay 2.2-fold (0.34 log units) below the measured number; the measured number falls inside the stated range.
By their numbers in this assay, from the lowest: compounds 1 and 2 (each within the scatter of the next); then compound 3.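

In this assay the group on the amide-type nitrogen proves able to move the number, since both the step of a 2.2-fold higher number from compound 1 to compound 3 (0.34 log units; beyond the scatter) and the step of a 2.1-fold higher number from compound 2 to compound 3 (0.33 log units; beyond the scatter) lie beyond the scatter, while the 4-ethoxyphenyl and 2,4-dichlorophenyl groups of the earlier pair could not be told apart. Among these three compounds, then, 2-methylphenyl is the one group that separates from the others, on the side of weaker inhibition, though both steps are modest and the earlier flat step did not hold as a rule for every aryl group at this position. No measurement is available that would explain this shift.

The compounds shown leave open whether the shift belongs to the methyl group itself or to where it sits on the phenyl ring, a question that 4-methylphenyl or unsubstituted phenyl on the same nitrogen would address. They also leave open how groups of another kind would behave there, such as a pyridine ring, a carboxylic acid or a morpholine.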